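A few compounds are considered here, and "the series" means these few. Any claim that something is new, unique, unknown or untested is made for them only; others in the source may bear on it.

In a functional assay on HepG2 cells (Homo sapiens) for antiproliferative activity, read by MTT assay, with a stated time of 48 h (a lower number here means a stronger inhibitor, a higher number a weaker inhibitor), three compounds sharing one core have been tested. Compound 1 `O=c1cc(-c2ccccc2)oc2cc(OCc3ccccc3)c(OCCCN3CCCC3)c(O)c12` gives 4200 nM in this assay. Compound 2 `CN1CCN(CCCOc2c(OCc3ccccc3)cc3oc(-c4ccccc4)cc(=O)c3c2O)CC1` gives 2400 nM, and compound 3 `CN1CCN(CCCCOc2c(OCc3ccccc3)cc3oc(-c4ccccc4)cc(=O)c3c2O)CC1` gives 2500 nM. Among these three numbers compound 3 has the second highest; its nearest neighbour is compound 2, with a 1.0-fold higher number from compound 2 to compound 3 (0.02 log units; within the scatter), and its furthest is compound 1, with a 1.7-fold lower number from compound 1 to compound 3 (0.23 log units; within the scatter). The remaining pair shows a 1.8-fold lower number from compound 1 to compound 2 (0.24 log units; within the scatter). All three steps therefore stay within the scatter of this assay, so on the numbers shown none of the three can be set apart from the others.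

Compound 4 `CN(C)CCCOc1c(OCc2ccccc2)cc2oc(-c3ccccc3)cc(=O)c2c1O` is the next compound in this series and has not yet been measured. It differs from compound 3 in one place: dimethylamino in place of (4-methylpiperazin-1-yl)methyl on a saturated chain carbon, three bonds along the chain from an oxygen on an aromatic ring. For the measured compounds named here, the steps that bear on this change are those that alter the amine at the end of the chain, a 1.8-fold lower number from compound 1 to compound 2 (0.24 log units; within the scatter) and a 1.7-fold lower number from compound 1 to compound 3 (0.23 log units; within the scatter), both within the scatter, and the one that changes only the chain length between compounds 2 and 3, likewise within the scatter. On this basis compound 4 is expected to show a 1.2-fold higher number from compound 3 to compound 4 (0.08 log units; within the scatter), that is, no step beyond the scatter in this assay. The estimated value for compound 4 is 3000 nM, with a range from 1200 nM to 7500 nM.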

Compound 4, half-maximal inhibitory concentration: 2200 nM
Compound 4: the middle estimate sits 1.4-fold (0.13 log units) above what was measured, within the range that was stated.
By their numbers in this assay, from the lowest: compounds 4, 2, 3 and 1 (each within the scatter of the next).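

Compound 4 brings an open-chain amine to this position, on a saturated chain carbon, three bonds along the chain from an oxygen on an aromatic ring, where compounds 1, 2 and 3 all carry a ring. In this assay, dimethylamino cannot be told apart from the ring amines: in place of (4-methylpiperazin-1-yl)methyl it gives (a 1.1-fold lower number from compound 3 to compound 4 (0.06 log units; within the scatter)), in place of 4-methylpiperazin-1-yl it gives (a 1.1-fold lower number from compound 2 to compound 4 (0.04 log units; within the scatter)), and in place of pyrrolidin-1-yl it gives (a 1.9-fold lower number from compound 1 to compound 4 (0.28 log units; within the scatter)). The ring at the chain end is therefore not needed to hold the number in this range, and nothing shown here explains why the change has so little effect.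

All four compounds end in an amine, so it remains open whether a chain ending in a hydroxyl group or a carboxylic acid would stay within the scatter of these compounds in this assay. Also open, as far as these compounds go, is whether a longer chain carrying dimethylamino or pyrrolidin-1-yl, or a smaller amine such as methylamino, would move the number beyond the scatter.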